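The source may report more compounds than this note shows. Statements on the series, on what has been measured and on what is new or still open speak of the compounds shown alone.

Measured so far in an ADME assay on Vero cells (Chlorocebus sabaeus) for cytotoxicity, read by resazurin assay, with a stated time of 3 days; a lower number here means a stronger inhibitor, a higher number a weaker inhibitor:
compound 1 `CCN(CC)c1cc2[nH]c(C3CCCCC3)nc2cc1NC(=O)c1cnccn1` — a limit only, > 100 ug/mL
compound 2 `CCOCCOC(=O)Nc1cc2nc(C3CCCCC3)[nH]c2cc1N(C)C` — a limit only, > 100 ug/mL
compound 3 `O=C(CCc1ccccc1)Nc1cc2nc(C3CCCCC3)[nH]c2cc1N1CCCC1` — a limit only, > 100 ug/mL

Compound 2 stands nowhere apart on these numbers: its reading in this assay is a limit, not a number, and the whole measured set sits the same way (the limit of > 100 ug/mL in this assay, at which 3 of the 3 values shown sit). Going by the values given here, with every value a limit, no step between measured compounds can be counted, and nothing in this assay separates the three amide-type substituents carried on the shared core.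

Compound 4 `CCc1ccc(C(=O)Nc2cc3nc(C4CCCCC4)[nH]c3cc2N(C)C)cc1` is the untested member. It differs from compound 2 in one place (4-ethylphenyl in place of 2-ethoxyethoxy on a carbonyl carbon), with the core and the dimethylamino group unchanged.

Among the compounds with values here, no measured step in this assay is available to scale the change, and the three limits give no direction to extrapolate. The step from compound 2 to compound 4 is therefore expected to be none beyond the scatter, a number no higher from compound 2 to compound 4 (the limit leaves the size open), with the reading most likely again a limit. Compound 4 is expected to give 100 ug/mL, within 40 ug/mL to 250 ug/mL.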

Compound 4, half-maximal inhibitory concentration: > 100 ug/mL
Compound 4: no number, only a limit (the forecaster's own chance of this, stated with the estimate: 70%); the middle value sits exactly at the limit.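

In this assay compound 4 gives > 100 ug/mL as a limit, not a number. Going by these compounds alone, compound 2 also reads as a limit, so no step between compound 2 and compound 4 can be read. Left open is whether any substituent on the shared core changes the reading in this assay at all: the limit of > 100 ug/mL in this assay, at which 4 of the 4 values shown sit.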